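This account rests on a few compounds, and the source may have more. Where it says the series, first, only, none or still open, it means among the compounds named here.

Compound 1 `Cc1nc(S(C)(=O)=O)ccc1Oc1ncnc(OC2CCN(C(=O)OC(C)(C)C(F)(F)F)CC2)c1F` gives 6.53 nM in a functional assay on isolated protein for inhibition of Glucose-dependent insulinotropic receptor (Homo sapiens), read by HTRF and cAMP accumulation; on this read-out higher numbers stand for an effect only at larger amounts of compound and lower numbers for an effect already at smaller amounts; compound 2 `Cc1nc(S(C)(=O)=O)ccc1Oc1ncnc(OC2CCN(C(=O)SC3CC3)CC2)c1F` gives 24.9 nM; compound 3 `Cc1nc(S(C)(=O)=O)ccc1Oc1ncnc(OC2CCN(C(=O)SC3CCC3)CC2)c1F` gives 8.51 nM.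

Compound 3 stands second highest of the three numbers, with compound 1 nearest, shown by a 1.3-fold higher number from compound 1 to compound 3 (0.12 log units; within the scatter), and compound 2 furthest, shown by a 2.9-fold lower number from compound 2 to compound 3 (0.47 log units; beyond the scatter). Compound 4 `CCc1cnc(C(=O)N2CCC(Oc3ncnc(Oc4ccc(S(C)(=O)=O)nc4C)c3F)CC2)nc1` differs from compound 3 in one place: 5-ethylpyrimidin-2-yl in place of cyclobutylsulfanyl on a carbonyl carbon. Going by the values given here, no measured pair swaps a group on the carbonyl carbon for an aromatic ring; the pairs that bear on this position are a 3.8-fold higher number from compound 1 to compound 2 (0.58 log units; beyond the scatter) and a 1.3-fold higher number from compound 1 to compound 3 (0.12 log units; within the scatter), both modest at most. A change of similar modest size in either direction is therefore expected for compound 4, shown as a 1.4-fold higher number from compound 3 to compound 4 (0.15 log units; within the scatter). Compound 4 is estimated at 12 nM, between 4 nM and 40 nM.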

Compound 4, half-maximal effective concentration: 4.7 nM
For compound 4 the middle estimate is 2.6-fold (0.41 log units) above the measured one; low and high end bracket the measured number.
By their numbers in this assay, from the lowest: compounds 4, 1 and 3 (each within the scatter of the next); then compound 2.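

On this carbonyl carbon, whose other neighbour is the amide-type nitrogen in a ring, an aromatic group can replace both cyclobutylsulfanyl (a 1.8-fold lower number from compound 3 to compound 4 (0.26 log units; within the scatter)) and 1-methyl-1-(trifluoromethyl)ethoxy (a 1.4-fold lower number from compound 1 to compound 4 (0.14 log units; within the scatter)) with both steps within the scatter. Compound 2 goes against this grouping of three unlike groups (a 5.3-fold lower number from compound 2 to compound 4 (0.72 log units; beyond the scatter)). Nothing measured here explains this.

The compounds shown leave open what a phenyl ring or an unsubstituted pyrimidin-2-yl would give on this carbonyl carbon. They also leave open what a longer chain in place of the ethyl would give.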